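A few compounds are considered here, and "the series" means these few. Any claim that something is new, unique, unknown or untested is made for them only; others in the source may bear on it.

Two compounds of the series have numbers in an assay on cells for displacement of a labelled ligand from prostaglandin E2 receptor EP4 subtype (Homo sapiens), read by scintillation counting (on this read-out higher numbers stand for weaker inhibition and lower numbers for stronger inhibition), so far. Compound 1 `Cc1oc(C(=O)O)cc1COc1ccc(-c2ccc(OC(F)(F)F)cc2)cc1` gives 2400 nM in this assay, and compound 2 `Cc1oc(C(=O)O)cc1COc1ccc(-c2ccccc2)cc1` gives 420 nM. Within the data shown here, the only single-point step between them, a 5.7-fold lower number from compound 1 to compound 2 (0.76 log units; beyond the scatter), runs from the substituted ring of compound 1 to the unsubstituted ring of compound 2. Among the measured compounds shown here, compound 2 therefore holds the lowest number of the two, with compound 1 as its only neighbour, a modestly higher one.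

Compound 3 `Cc1oc(C(=O)O)cc1COc1ccc(-c2ccc(S(C)(=O)=O)cc2)cc1` has not yet been measured in this assay. Against compound 2 it shows (methylsulfonyl in place of hydrogen on an aromatic carbon), so a group is again placed on the aromatic carbon para to the large group, where compound 1 carried trifluoromethoxy. For the measured compounds named here, the one step that bears on this position, a 5.7-fold lower number from compound 1 to compound 2 (0.76 log units; beyond the scatter), shows that clearing that position lowered the number modestly; the reverse operation with a different group is the only guide available, and nothing on methylsulfonyl itself is known here. A modest rise beyond the scatter is therefore expected for compound 3, a 2.4-fold higher number from compound 2 to compound 3 (0.38 log units; beyond the scatter), though smaller than the step seen with trifluoromethoxy. Compound 3 is estimated at 1000 nM, within 300 nM to 3500 nM.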

Compound 3, inhibition constant: > 10000 nM
Compound 3: a limit, no number; the forecaster's own chance of this, stated with the estimate: 5%; middle value at least 10-fold (1.00 log units) away from the limit.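

Among these compounds, on the aromatic carbon para to a large group, methylsulfonyl in place of hydrogen gives an at least 23-fold higher number from compound 2 to compound 3 (1.37 log units; beyond the scatter), a large step, whereas the only earlier step at this place, a 5.7-fold lower number from compound 1 to compound 2 (0.76 log units; beyond the scatter), was modest. Methylsulfonyl in place of trifluoromethoxy gives an at least 4.1-fold higher number from compound 1 to compound 3 (0.61 log units; beyond the scatter), so in this assay the outcome at this carbon depends on which group enters, and the two groups shown are not equivalent even though both give higher numbers than hydrogen does. The reading for compound 3 is a limit of the assay and not a number: the limit of > 10000 nM in this assay, at which 1 of the 3 values shown sits.

From the compounds shown here alone, compound 2, at 420 nM, remains the lowest of the series, and with only trifluoromethoxy and methylsulfonyl on this carbon it stays open whether any group here can match or improve on hydrogen. Going by these compounds, a fluorine atom, a methyl group, an amine or a carboxylic acid on the same carbon would show whether the rise follows the size of the group or its kind, and the true distance of compound 3 from compound 2 also stays open.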